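A few compounds are considered here, and "the series" means these few. Any claim that something is new, unique, unknown or untested is made for them only; others in the source may bear on it.

Measured so far:

Compound 1 `CCOC(=O)c1cc(NC/C=C/c2cccc(C(=N)N)c2)ccc1OC1CCN(C(C)=N)CC1`: 40 nM
Compound 2 `N=C(N)c1ccc(O)c(/C=C/CNc2ccc(OC3CCN(C(N)=O)CC3)c(C(F)(F)F)c2)c1`: 520 nM

Both compounds were tested in an assay on isolated protein for inhibition of serine protease 1 (Bos taurus); a lower number here means a stronger inhibitor, a higher number a weaker inhibitor. Compound 1 gives 40 nM, and compound 2 gives 520 nM, so of the two numbers compound 1 has the lower one and the stronger inhibition; the two compounds differ in more than one place, so what exactly drives the gap between them cannot be told from these two alone.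

Compound 3 `CC(=N)N1CCC(Oc2ccc(NC/C=C/c3cccc(C(=N)N)c3)cc2[N+](=O)[O-])CC1` is the next structure. It keeps everything of compound 1 except one group: nitro in place of ethoxycarbonyl on an aromatic carbon. Within the data shown here, no pair of measured compounds shows this kind of exchange, so there is no measured step to lean on. The group leaving and the group entering are both without a hydrogen-bond donor and each brings two acceptors, so the change looks modest. The step in this assay from compound 1 to compound 3 is expected to be small, a 1.3-fold higher number from compound 1 to compound 3 (0.10 log units; within the scatter), within the usual scatter or only slightly beyond it. Compound 3 is therefore estimated at 50 nM, with a likely range from 15 nM to 160 nM.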

Compound 3, inhibition constant: 27 nM
Estimate against measurement, compound 3: 1.9-fold (0.27 log units) above, and the stated range covers the measured number.
By their numbers in this assay, from the lowest: compounds 3 and 1 (each within the scatter of the next); then compound 2.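

In this assay, putting nitro in place of ethoxycarbonyl on this aromatic carbon, ortho to a large group and meta to a large group, gives a 1.5-fold lower number from compound 1 to compound 3 (0.17 log units; within the scatter). The two compounds therefore cannot be told apart by this measurement. At this position, the full ethoxycarbonyl group is not needed to keep this level of inhibition, since nitro has fewer heavy atoms and no carbon, while the counts of hydrogen-bond donors and acceptors stay the same. No measurement at hand explains why the two groups read alike.

From the compounds shown here alone, it remains open how a plain hydrogen, an amine or a carboxylic acid on this carbon would read. The trifluoromethyl group of compound 2 offers no direct comparison, since that compound differs from the others in more than one place.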